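Benzyl-substituted nucleoside series: antiproliferative notes

The source may hold more compounds than are shown below. What is called first, only, known or untested is meant among the compounds shown, and "the series" means these compounds.

Measured so far:
- compound 1, `OC[C@H]1O[C@@H](n2cnc3c(NCc4cccc(F)c4)ncnc32)[C@H](O)[C@@H]1O`: 920 nM
- compound 2, `OC[C@H]1O[C@@H](n2cnc3c(NCc4ccc(F)cc4)ncnc32)[C@H](O)[C@@H]1O`: 1200 nM
- compound 3, `OC[C@H]1O[C@@H](n2cnc3c(NCc4ccccc4Br)ncnc32)[C@H](O)[C@@H]1O`: 6600 nM

In a functional assay on HL-60 cells (Homo sapiens) for antiproliferative activity, with a stated time of 72 h (a higher number here means a weaker inhibitor, a lower number a stronger inhibitor), compound 1 gives the lowest number of the three. Compound 2 sits close to it, with a 1.3-fold higher number from compound 1 to compound 2 (0.12 log units; within the scatter), a change of 4-fluorophenyl in place of 3-fluorophenyl that does not separate the two. Compound 3 is the outlier: a 7.2-fold higher number from compound 1 to compound 3 (0.86 log units; beyond the scatter) and a 5.5-fold higher number from compound 2 to compound 3 (0.74 log units; beyond the scatter) show that 2-bromophenyl in place of either fluorophenyl costs a modest but real amount in this assay.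

Compound 4, `Cc1cccc(CNc2ncnc3c2ncn3[C@@H]2O[C@H](CO)[C@@H](O)[C@H]2O)c1`, has not yet been measured. Relative to compound 1 the change is methyl in place of fluoro on an aromatic carbon. Among the measured compounds shown here, none of the measured steps swaps fluoro for methyl, so no direct precedent exists. For the measured compounds named here, what the data do show is that changes on the benzyl ring that keep a small substituent away from the 2-position leave this assay nearly unchanged, while the 2-bromophenyl shift is the only one that moves the number beyond the scatter.

A step within the scatter is therefore expected for compound 4, a 1.1-fold higher number from compound 1 to compound 4 (0.04 log units; within the scatter), with the number staying near that of compound 1. The estimate for compound 4 is 1000 nM, ranging from 450 nM to 2300 nM.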

Compound 4, half-maximal inhibitory concentration: 6400 nM
Estimate against measurement, compound 4: 6.4-fold (0.81 log units) below, and the stated range ends below it.
By their numbers in this assay, from the lowest: compounds 1 and 2 (each within the scatter of the next); then compounds 4 and 3 (each within the scatter of the next).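

In this assay, methyl in place of fluoro on an aromatic carbon, meta to a large group, gives a 7.0-fold higher number from compound 1 to compound 4 (0.84 log units; beyond the scatter), so a step beyond the scatter is no longer confined to 2-bromophenyl, and the identity of a single-atom substituent at this place matters. The same split appears against the other fluoro compound, with a 5.3-fold higher number from compound 2 to compound 4 (0.73 log units; beyond the scatter), whereas a 1.0-fold lower number from compound 3 to compound 4 (0.01 log units; within the scatter), leaving compounds 1 and 2 together at one level and compounds 3 and 4 together at another. Nothing measured on these compounds accounts for the difference between fluoro and methyl here.

The compounds shown leave open whether 3-fluorophenyl is the unusual member or 3-methylphenyl is, a question that the unsubstituted benzyl group, or chloro or methoxy at the same place, would help to settle. Also open, on these data alone, is whether the methyl result holds elsewhere on the ring, as 4-methylphenyl would show, and whether 3-bromophenyl would stay with compounds 1 and 2 or fall with compounds 3 and 4.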